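The source may hold more compounds than are shown below. What is called first, only, known or untested is meant among the compounds shown, and "the series" means these compounds.

Compound 1 `O=C1c2ccccc2N(Cc2ccccc2Cl)S(=O)(=O)N1Cc1ccccc1` is the reference point of this small set. Among the measured compounds shown here, in a functional assay on HEL cells (Homo sapiens) for inhibition (on this read-out lower numbers stand for higher toxicity in this test and higher numbers for lower toxicity in this test), compound 1 gives 88000 nM, the only outright number among the three measured compounds. Compound 2 `O=C1c2ccccc2N(Cc2ccccc2Cl)S(=O)(=O)N1COCc1ccccc1` reaches only the limit > 50000 nM in this assay. Compound 3 `O=S1(=O)N=C(OCc2ccccc2)c2ccccc2N1Cc1ccc(Cl)c(Cl)c1` likewise stays at the limit > 200000 nM in this assay. For the measured compounds named here, the single step between measured compounds that differ in one place, a step that the limit leaves unreadable from compound 1 to compound 2, therefore has no readable size, because it runs into the limit (the limit of > 50000 nM in this assay, at which 1 of the 3 values shown sits).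

The change followed here is benzyloxy in place of 2-chlorophenyl on a saturated chain carbon bound to a sulfonamide nitrogen in a ring, which yields compound 4 `O=C1c2ccccc2N(COCc2ccccc2)S(=O)(=O)N1Cc1ccccc1`. Going by the values given here, it is the same kind of exchange as the one from compound 1 to compound 2, now made at the sulfonamide nitrogen in the ring rather than at the amide-type nitrogen, and that earlier step gave nothing beyond an unreadable move toward the limit. Every measured value in this assay sits at the weak end of the read-out, and nothing in the set points to a step beyond the scatter in either direction. Compound 4 is thus expected to give about 100000 nM in this assay, somewhere between 40000 nM and 250000 nM. The expected step is a 1.1-fold higher number from compound 1 to compound 4 (0.06 log units; within the scatter), essentially flat.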

Compound 4, half-maximal cytotoxic concentration: > 122000 nM
Compound 4: no number, only a limit; the forecaster's own chance of this, stated with the estimate: 50%; at least 1.2-fold (0.08 log units) between middle value and limit.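

In this assay compound 4 gives > 122000 nM, which is a limit and not a number. Benzyloxy in place of 2-chlorophenyl on a saturated chain carbon bound to a sulfonamide nitrogen in a ring gives an at least 1.3-fold higher number from compound 1 to compound 4 (0.14 log units; that floor lies within the scatter), so this step has a readable floor and direction, although that floor does not clear the scatter. Among the compounds shown here, the earlier step at the amide-type nitrogen cannot be read, so compound 4 provides the only readable evidence on a benzyloxy exchange in this set: at the sulfonamide nitrogen, replacing 2-chlorobenzyl with (benzyloxy)methyl gives no sign of a lower number on this read-out.

On these data alone, how far the true value of compound 4 lies past its limit stays open, and so does whether the step exceeds the scatter at all. Also open, as far as these compounds go, is whether an amine or a carboxylic acid on that saturated chain carbon would give an outright number in this assay, and whether such a number would differ from that of compound 1 by more than the scatter.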